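The compounds below may be only part of what the source reports. "The series", "measured", "known", "first", "only" and "open" are said of these compounds alone.

Compound 3 `O=C(Nc1ccc(NS(=O)(=O)C(F)(F)F)c(F)c1)c1cccc(C(F)(F)F)c1` gives the lowest number of the two numbers measured in an ADME assay on RAW264.7 cells (Mus musculus) for cytotoxicity, read by MTT assay, with a stated time of 48 h; a lower number here means a stronger inhibitor, a higher number a weaker inhibitor: compound 3 gives 34400 nM. Compound 1 `CS(=O)(=O)Nc1ccc(NC(=O)c2cc(C(F)(F)F)cc(C(F)(F)F)c2)cc1F` gives 125000 nM in this assay. Compound 2 `CCS(=O)(=O)Nc1ccc(NC(=O)c2cc(C(F)(F)F)cc(C(F)(F)F)c2)cc1F` gives only a limit of the assay in this assay, namely > 250000 nM. Within the data shown here, the one measured step, an at least 2.0-fold higher number from compound 1 to compound 2 (0.30 log units; that floor lies within the scatter), concerns a change on the sulfonyl side and reaches the limit described by the limit of > 250000 nM in this assay, at which 1 of the 3 values shown sits, so it cannot be read as a number. Compound 4 `O=C(Nc1ccc(NS(=O)(=O)C(F)(F)F)c(F)c1)c1cc(C(F)(F)F)cc(C(F)(F)F)c1` differs from compound 3 in a single place: trifluoromethyl in place of hydrogen on an aromatic carbon. Among the measured compounds shown here, no measured step covers this change, since no pair of measured compounds differs only by a further trifluoromethyl on that ring; the one measured step touches a different part of the shared core and so offers no guide to size or direction. For this reason the step is expected to stay within the scatter, as a 1.2-fold higher number from compound 3 to compound 4 (0.07 log units; within the scatter). Compound 4 is therefore estimated at 40000 nM in this assay, with a range from 15000 nM to 110000 nM.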

Compound 4, half-maximal inhibitory concentration: 112000 nM
Estimate against measurement, compound 4: 2.8-fold (0.45 log units) below; the whole stated range lies below it.
By their numbers in this assay, from the lowest: compound 3; then compounds 4 and 1 (each within the scatter of the next). At a limit, above all of these: compound 2.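

In this assay, trifluoromethyl in place of hydrogen on an aromatic carbon, meta to a trifluoromethyl group, gives a 3.3-fold higher number from compound 3 to compound 4 (0.51 log units; beyond the scatter): this step lies beyond the scatter, and the earlier measured step concerned only the sulfonyl side. With both trifluoromethyl groups on the ring, trifluoromethyl in place of methyl on the sulfonyl sulfur gives a 1.1-fold lower number from compound 1 to compound 4 (0.05 log units; within the scatter), which lies within the scatter. Compound 2 gives > 250000 nM, a limit and not a number. Trifluoromethyl in place of ethyl on the sulfonyl sulfur gives an at least 2.2-fold lower number from compound 2 to compound 4 (0.34 log units; beyond the scatter), a step that starts from this limit, so its full size cannot be read: the limit of > 250000 nM in this assay, at which 1 of the 4 values shown sits.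

The compounds shown leave open whether a methyl, a chlorine or an amine on this aromatic carbon would raise the number as trifluoromethyl does. They also leave open whether this step would be the same size with methyl on the sulfonyl sulfur.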